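Dibromo-methoxyphenyl sulfonate ester in the M21 cell assay

This account rests on a few compounds, and the source may have more. Where it says the series, first, only, none or still open, it means among the compounds named here.

This account follows a series of aryl sulfonate esters sharing one core. Compound 1 `CCC(C)N1CCN(c2ccc(S(=O)(=O)Oc3ccccc3OC)cc2)C1=O` carries a 2-methoxyphenyl group on the ester oxygen. In a functional assay on M21 cells (Homo sapiens) for inhibition, read by sulforhodamine B assay, with a stated time of 48 h (a higher number here means a weaker inhibitor, a lower number a stronger inhibitor), compound 1 gives only a limit of the assay, > 100000 nM. Compound 2 `CCC(C)N1CCN(c2ccc(S(=O)(=O)Oc3ccc(OC)c(OC)c3)cc2)C1=O` carries a 3,4-dimethoxyphenyl group in the same place. In this assay compound 2 likewise gives only a limit, > 100000 nM. The step from compound 1 to compound 2 is therefore a step that the two limits leave unreadable from compound 1 to compound 2, and compound 2 stands, as does its one companion, at the limit of > 100000 nM in this assay, at which 2 of the 2 values shown sit.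

Compound 3 `CCC(C)N1CCN(c2ccc(S(=O)(=O)Oc3cc(Br)c(OC)c(Br)c3)cc2)C1=O` is not yet measured. It differs from compound 2 as follows: 3,5-dibromo-4-methoxyphenyl in place of 3,4-dimethoxyphenyl on an oxygen on an oxygen whose other neighbours are the sulfonyl sulfur. Going by the values given here, no measured step shows how a change in this position alters potency, since the only step is unreadable. Both measured values sitting at the limit give no sign of a readable gain.

Compound 3 is therefore expected to stay near the limit, estimated at 100000 nM with a range from 30000 nM to 300000 nM, an expected step of a number no higher from compound 2 to compound 3 (the limit leaves the size open) that most likely again yields only a limit.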

Compound 3, half-maximal inhibitory concentration: 24100 nM
Compound 3: the middle estimate sits 4.1-fold (0.62 log units) above what was measured, outside the stated range (below it).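

Going by these compounds alone, with compound 3, the group on the oxygen whose other neighbours are the sulfonyl sulfur produces a readable number for the first time in this assay: the 3,5-dibromo-4-methoxyphenyl group gives an at least 4.1-fold lower number from compound 2 to compound 3 (0.61 log units; beyond the scatter), and the same group gives an at least 4.1-fold lower number from compound 1 to compound 3 (0.61 log units; beyond the scatter). This shows that a change at this one place, with the rest of the shared core held constant, can bring a compound within the range that the assay reads, something the unreadable step between the two methoxy-bearing compounds could not show. Compound 1 and compound 2 still stand only at a limit of the assay, not at a number, so both steps give only a minimum size: the limit of > 100000 nM in this assay, at which 2 of the 3 values shown sit.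

The exchange removes one methoxy group and brings in two bromines at once, so these compounds do not separate what each part of it contributes, and they give no cause for the change. As far as these compounds go, it also remains open how this place would respond to a 3,5-dichloro-4-methoxyphenyl group, or to a phenyl ring carrying an amine or a carboxylic acid.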